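The source may report more compounds than this note shows. Statements on the series, on what has been measured and on what is new or still open speak of the compounds shown alone.

The series rests on a shared core carrying a methoxy group, an enone chain and a triazole linked through a benzylic ether, and it was examined in a functional assay on PC-3 cells (Homo sapiens) for antiproliferative activity, read by MTT assay, with a stated time of 48 h; on this read-out higher numbers stand for weaker inhibition and lower numbers for stronger inhibition. Compound 2 `COc1cccc(-n2cc(COc3ccc(/C=C/C(C)=O)cc3OC)nn2)c1` carries a 3-methoxyphenyl on the triazole nitrogen; in this assay compound 2 gives 31600 nM. Compound 1 `COc1cc(/C=C/C(C)=O)ccc1OCc1cn(-c2ccc(/N=N/c3ccccc3)cc2)nn1` carries instead a phenylazophenyl group, and in this assay compound 1 gives 42100 nM. The gap between these two values lies within the usual scatter of such measurements, so the two compounds cannot be told apart on these numbers. Compound 3 `COc1cc(/C=C/C(C)=O)ccc1OCc1cn(-c2ccc([N+](=O)[O-])cc2)nn1` has not been measured; it differs from compound 2 in one place: 4-nitrophenyl in place of 3-methoxyphenyl on an aromatic nitrogen. Among the compounds with values here, no measured pair shows what this exchange does here. Since the two measured compounds sit so close to each other, the expectation for compound 3 is a step from compound 2 of about a 1.0-fold higher number from compound 2 to compound 3 (0.01 log units; within the scatter), which amounts to no change beyond the scatter. On that basis compound 3 is estimated to give 32000 nM, with a range from 10000 nM to 95000 nM.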

Compound 3, half-maximal inhibitory concentration: 46700 nM
Beside the measured number, compound 3's estimate is 1.5-fold (0.16 log units) below it; measured number inside the range.
By their numbers in this assay, from the lowest: compounds 2, 1 and 3 (each within the scatter of the next).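

Placing 4-nitrophenyl in place of 3-methoxyphenyl on an aromatic nitrogen gives a 1.5-fold higher number from compound 2 to compound 3 (0.17 log units; within the scatter) in this assay, which is the first direct reading of this exchange, and on these numbers compound 2 and compound 3 cannot be told apart. The other step concerns an aromatic carbon, where a group of 3 heavy atoms with no ring stands in place of a group of 8 heavy atoms containing a six-membered aromatic ring; it gives a 1.1-fold higher number from compound 1 to compound 3 (0.05 log units; within the scatter) in this assay, so even this exchange of a ring-bearing group for one without a ring cannot be separated from the scatter. Nothing on hand bears on why the three compounds lie so close together.

The compounds shown leave open whether a group of another kind on the aromatic nitrogen, such as a cyclohexyl ring or a longer alkyl chain, would give a step beyond the scatter. They also leave open whether an amine or a carboxylic acid on the aromatic ring attached to that nitrogen would move the number in this assay, and what a change to the enone chain of the shared core would do.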